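The compounds below may be only part of what the source reports. "The series", "measured", "known", "first", "only" and "open" are said of these compounds alone.

Compound 1, `CSCC[C@H](NC(=O)c1ccc(NCc2cncn2Cc2cccc(C#N)c2)cc1-c1ccccc1)C(=O)O`, in a functional assay on NIH3T3 cells (Mus musculus) (a higher number here means that more compound is needed for the effect, a lower number that less compound is needed), gives > 10 uM, which is a limit of the assay rather than a number.
Compound 2, `COC(=O)[C@H](CCSC)NC(=O)c1ccc(CNCc2cncn2Cc2ccc(C#N)cc2)cc1-c1ccccc1C`, in this assay gives > 10 uM, again a limit.
Compound 3, `COC(=O)[C@H](CCSC)NC(=O)c1ccc(CN(Cc2c[nH]cn2)Cc2c[nH]cn2)cc1-c1ccccc1C`, in this assay gives > 10 uM, also a limit.

Compound 1 therefore stands where every measured compound stands: at the limit of > 10 uM in this assay, at which 3 of the 3 values shown sit. For the measured compounds named here, no number is known for it, and no step between two measured compounds can be read from these values, so nothing here shows how any change on the shared core moves the read-out.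

Compound 4, `CSCC[C@H](NC(=O)c1ccc(NCc2cncn2Cc2ccc(C#N)cc2)cc1-c1ccccc1)C(=O)O`, is the not yet measured partner of compound 1. The two differ in one place: 4-cyanophenyl in place of 3-cyanophenyl on a saturated chain carbon bound to an aromatic nitrogen. Going by the values given here, since the three measured values give no step to lean on, the expectation for this assay is a step of no size beyond the usual scatter, with no direction favoured. Compound 4 is accordingly expected to sit at the limit as well, with an estimated value of 15 uM and a range from 5 uM to 50 uM. The estimated step that the limit leaves unreadable from compound 1 to compound 4 is expected to be essentially nil.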

Compound 4, concentration for half-maximal effect: > 10 uM
Compound 4 ended at the assay's limit; the forecaster's own chance of this, stated with the estimate: 80%; the middle value lies beyond the limit too.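

No step can be read between compound 1 and compound 4: in this assay each stands at a limit of the assay, not at a number. The compounds shown leave open whether any change on the shared core moves the read-out, and in which direction.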